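The source may report more compounds than this note shows. Statements on the series, on what has been measured and on what is new or still open speak of the compounds shown alone.

Of the compounds shown here, three built on one shared core have been tested in a functional assay on A-375 cells (Homo sapiens) for antiproliferative activity, read by CCK-8 assay, with a stated time of 72 h, tested at 8 uM; on this read-out lower numbers stand for a weaker effect and higher numbers for a stronger effect at the one concentration tested. Compound 1 `Nc1ccccc1NC(=O)c1ccc(CSC(=S)N2CCN(Cc3ccccn3)CC2)cc1` gives 82.4%. Compound 2 `Nc1ccccc1NC(=O)c1ccc(CSC(=S)N2CCc3ccccc32)cc1` gives 85.4%, and compound 3 `Nc1ccccc1NC(=O)c1ccc(CSC(=S)N2CCCC2)cc1` gives 89.5%. Both of these numbers lie within the usual scatter of the number for compound 1, so the three compounds cannot be told apart on this read-out. Within the data shown here, the only step between two measured compounds that differ in a single place is a number 4.1 percentage points higher from compound 2 to compound 3 (within the scatter), an exchange on the thiocarbonyl carbon, and it too stays inside the scatter.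

Compound 4 `Nc1ccccc1NC(=O)c1ccc(CSC(=S)N2CCN(Cc3ccccc3)CC2)cc1` has not yet been measured. It differs from compound 1 in one place: phenyl in place of pyridin-2-yl on a saturated chain carbon bound to an amine nitrogen in a ring. Among the measured compounds shown here, no measured pair shows what this exchange does, since the one measured step concerns a different part of the molecule and does not itself leave the scatter. With nothing pointing either way, the expectation is a step in this assay that stays within the scatter, a number 0.6 percentage points higher from compound 1 to compound 4 (within the scatter). Compound 4 is therefore estimated at 83%, with a likely range from 70% to 93%.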

Compound 4, a percentage reported as inhibition, at one concentration (the size of the read-out at that concentration, not a potency): 29.3%
Estimate against measurement, compound 4: 53.7 percentage points above; the whole stated range lies above it.
By their numbers in this assay, from the lowest: compound 4; then compounds 1, 2 and 3 (each within the scatter of the next).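

This position is far from indifferent. In this assay, phenyl in place of pyridin-2-yl on a saturated chain carbon bound to an amine nitrogen in a ring gives a number 53.1 percentage points lower from compound 1 to compound 4 (beyond the scatter), whereas the earlier exchange on the thiocarbonyl carbon stayed within the scatter. Both groups are six-membered aromatic rings with the same count of heavy atoms, and the counted difference is that pyridin-2-yl carries a ring nitrogen and a hydrogen-bond acceptor while phenyl has neither, so a small change to the structure can separate two compounds sharply on this read-out; no measurement here explains the drop.

The compounds shown leave open whether the ring nitrogen itself is what matters, or whether another group could restore the higher number seen for compound 1. An amine or a hydroxyl group on the phenyl ring of compound 4, or a longer chain in place of the single carbon that carries the ring, would extend the comparison at this position.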